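The compounds below may be only part of what the source reports. "The series", "measured", "known", "first", "only" and "open" are said of these compounds alone.

Measured so far in a functional assay (spleen, spleen) for activation, with Mus musculus as the target; on this read-out higher numbers stand for an effect only at larger amounts of compound and lower numbers for an effect already at smaller amounts:

compound 1, `CCCCCOc1nc(N)c2nc(O)n(Cc3ccccc3)c2n1`, gives 0.01 uM.
compound 2, `Nc1ncnc2c1nc(Cl)n2Cc1ccccc1`, gives only a limit, > 10 uM.
compound 3, `Nc1ncnc2c1nc(I)n2Cc1ccccc1`, gives only a limit, > 10 uM.

Within the data shown here, compound 1 is the one compound of the three with a number; the other two sit at the limit of > 10 uM in this assay, at which 2 of the 3 values shown sit. Among the measured compounds shown here, the one step between measured compounds, a step that the two limits leave unreadable from compound 2 to compound 3, runs from one limit to another and its size cannot be read.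

Compound 4, `CCCC[S+]([O-])c1nc(N)c2nc(O)n(Cc3ccccc3)c2n1`, differs from compound 1 in one place: a group of 6 heavy atoms (4 carbon, 1 oxygen, 1 sulfur; no ring) in place of a group of 6 heavy atoms (5 carbon, 1 oxygen; no ring), on an aromatic carbon. For the measured compounds named here, none of the measured steps bears on this change: the single step measured concerns the substituent on the five-membered ring of a core that also lacks the hydroxy group and the group on the six-membered ring, and it is unreadable. The expectation for compound 4 therefore rests on the step being a like-for-like exchange of two chains of the same atom count at the same place of the core of compound 1, with no comparison in this assay to set its size. Compound 4 is expected to give 0.1 uM, within 0.01 uM to 1 uM. The step this estimate implies is a 10-fold higher number from compound 1 to compound 4 (1.00 log units; beyond the scatter), a guess of modest loss kept within a wide range in this assay.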

Compound 4, minimum effective concentration: 0.01 uM
Compound 4: middle estimate off by 10-fold (1.00 log units), on the high side; the range from low to high includes it.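

In this assay, replacing pentyloxy with the chain of compound 4, which holds sulfur and oxygen, on the aromatic carbon between two ring nitrogen atoms gives no change at the digits printed from compound 1 to compound 4 (within the scatter). Among these compounds, this is the first reading at this position: on the core of compound 1, a chain carrying sulfur in place of a carbon and the oxygen is accepted without a change that can be told from scatter, so the ether oxygen of pentyloxy is not required at this place for the effect in this pair. The only earlier step concerns a different place on a different core and cannot be read, and nothing shown accounts for the outcome of this exchange.

Going by these compounds, whether this position accepts groups further from these two remains open, for example a shorter chain such as ethoxy, a longer chain such as octyloxy, an amine or a carboxylic acid. Also open is how much the hydroxy group and the group on the six-membered ring contribute on their own, as no pair shown differs in only one of those places.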